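The source may hold more compounds than are shown below. What is called first, only, known or untested is meant among the compounds shown, and "the series" means these compounds.

Compound 1 `CCCCC[Se]c1nc(NCc2ccc(SC)cc2)c2ccccc2n1` gives > 100000 nM in a functional assay on HT-29 cells (Homo sapiens) for cytotoxicity, read by MTT assay, with a stated time of 72 h (on this read-out lower numbers stand for higher toxicity in this test and higher numbers for lower toxicity in this test), a value that is a limit of the assay and not a number.
Compound 2 `CCCCCSc1nc(NCc2ccc([Se]C)cc2)c2ccccc2n1` gives > 100000 nM in this assay, again a limit of the assay rather than a number.

Compound 2 therefore stands where the reported values stop rather than at a measured point, and it shares this position with compound 1: the limit of > 100000 nM in this assay, at which 2 of the 2 values shown sit. Going by the values given here, no step between measured compounds can be drawn here, since compound 1 and compound 2 differ in more than one place, so their two values show only that each sits at the limit.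

Compound 3 `CSc1nc(NCc2ccc([Se]C)cc2)c2ccccc2n1` is the next compound to be measured in this assay. It differs from compound 2 by hydrogen in place of butyl on a saturated chain carbon bound to a sulfur. With both known values resting at the limit, nothing in the data points to a direction for this change, and the step expected from compound 2 to compound 3 is a step that the limit leaves unreadable from compound 2 to compound 3, none beyond the usual scatter. Compound 3 is accordingly estimated at 150000 nM, within a range from 50000 nM to 500000 nM, and it is expected that the assay will most likely again report only a limit.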

Compound 3, concentration lethal to 50% of the cells: > 100000 nM
Compound 3: a limit, no number; the forecaster's own chance of this, stated with the estimate: 80%; the middle value is on the limit's open side.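

No step can be read from compound 2 to compound 3, since each value is a limit of the assay and not a number: the limit of > 100000 nM in this assay, at which 3 of the 3 values shown sit.

The compounds shown leave open how toxic any of them is in this assay, and whether hydrogen in place of butyl changes that toxicity at all.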